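Shrinking the Piperidine Ring on a Chromone Dithiocarbamate

The compounds below may be only part of what the source reports. "The series", "measured", "known", "first", "only" and "open" are said of these compounds alone.

Three chromone dithiocarbamates have been tested in a functional assay on SW480 cells (Homo sapiens) for antiproliferative activity, read by MTT assay, with a stated time of 72 h; a higher number here means a weaker inhibitor, a lower number a stronger inhibitor. Compound 1 `O=c1c(CSC(=S)N2CCCCC2)coc2cc(Cl)ccc12` gives 790 nM in this assay, the lowest of the two numbers reported. Compound 3 `COc1ccc2occ(CSC(=S)N3CCCC3)c(=O)c2c1` gives 4800 nM in this assay, a higher number than compound 1 and beyond the scatter. Compound 2 `CCOC(=O)c1cc(=O)c2cc(CSC(=S)N(C)c3ccccc3)ccc2o1` reports only a limit, > 25000 nM, in this assay; one of the three values sits at this limit (the limit of > 25000 nM in this assay, at which 1 of the 3 values shown sits). Compound 4 `O=c1c(CSC(=S)N2CCCC2)coc2cc(Cl)ccc12` has not yet been measured in this assay. It differs from compound 1 in a single place: pyrrolidin-1-yl in place of piperidin-1-yl on a thiocarbonyl carbon. Among the measured compounds no pair differs in one place only, so the size of such a step is not known here; compound 3 carries the pyrrolidin-1-yl group but on a different core, and its value cannot be read as the effect of the ring change alone. Compound 4 is expected to show a small step, if any, toward a weaker inhibitor, a 1.6-fold higher number from compound 1 to compound 4 (0.22 log units; within the scatter), with its estimated value at 1300 nM and a likely range from 400 nM to 4500 nM in this assay.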

Compound 4, half-maximal inhibitory concentration: 7800 nM
Estimate against measurement, compound 4: 6.0-fold (0.78 log units) below; the whole stated range lies below it.
By their numbers in this assay, from the lowest: compound 1; then compounds 3 and 4 (each within the scatter of the next). At a limit, above all of these: compound 2.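

Going by these compounds alone, with compound 4, the ring on the thiocarbonyl carbon can be read on its own, since the earlier compounds all differ from one another in more than one place. On the core of compound 1, in this assay, pyrrolidin-1-yl in place of piperidin-1-yl gives a 9.9-fold higher number from compound 1 to compound 4 (0.99 log units; beyond the scatter). This position is therefore sensitive to ring size on this core, and the six-membered ring gives the stronger inhibitor of the pair.

Nothing shown here accounts for the size of this step. From the compounds shown here alone, it also remains open whether the same step holds on other cores, and whether a morpholin-4-yl ring or an open-chain diethylamino group at this place would stand nearer to compound 1 or to compound 4.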